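Removing the hydroxy from compound 1

A few compounds are considered here, and "the series" means these few. Any claim that something is new, unique, unknown or untested is made for them only; others in the source may bear on it.

- Compound 1 `N#Cc1ccc(NC(=O)c2ccc3ccccc3c2O)cc1` gives 2720 nM as its value
- Compound 2 `N#Cc1ccc(NC(=O)c2ccc(Br)cc2O)cc1Cl` gives 960 nM as its value

In a functional assay on KG-1 cells (Homo sapiens) for cytotoxicity, read by luminescence and CellTiter-Glo, with a stated time of 3 days (on this read-out higher numbers stand for weaker inhibition and lower numbers for stronger inhibition), compound 1 stands at 2720 nM as the higher of the two numbers, so it is the weaker inhibitor, and the gap to compound 2 lies beyond the usual scatter.

Compound 3 `N#Cc1ccc(NC(=O)c2ccc3ccccc3c2)cc1` has not yet been measured. It differs from compound 1 in one place, with hydrogen in place of hydroxy on an aromatic carbon. Within the data shown here, both measured compounds carry a hydroxy group, so no measured pair shows this change directly, and any forecast is uncertain. A rise in the number seems more likely than a fall, and this expected change, a 2.6-fold higher number from compound 1 to compound 3 (0.41 log units; beyond the scatter) in size, would mean weaker inhibition in this assay if it holds. For compound 3 the estimate is 7000 nM with an expected range from 2000 nM to 25000 nM on this read-out.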

Compound 3, half-maximal inhibitory concentration: > 10000 nM
Compound 3 was reported as a limit (the forecaster's own chance of this, stated with the estimate: 25%); middle value at least 1.4-fold (0.15 log units) away from the limit.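

In this assay, compound 3 is reported only as a limit, > 10000 nM. Replacing the hydroxy on this aromatic carbon with hydrogen gives an at least 3.6-fold higher number from compound 1 to compound 3 (0.56 log units; beyond the scatter), which offers the first direct view of this position and shows that, within this pair, keeping the hydroxy goes with stronger inhibition. The step has a known lower bound but no known upper bound, because of one reported value: the limit of > 10000 nM in this assay, at which 1 of the 3 values shown sits.

Hydrogen is the only replacement shown here, so it remains open whether a methoxy group, an amine or a fluorine atom on this carbon would preserve the activity of compound 1. Going by these compounds, it is also open whether removing the hydroxy from compound 2 would have a similar effect on its different core.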